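From compound 1 to compound 4: one group exchanged

A few compounds are considered here, and "the series" means these few. Any claim that something is new, unique, unknown or untested is made for them only; others in the source may bear on it.

Measured in a functional assay on HOS-TE85 cells (Homo sapiens) for inhibition, read by CCK-8 assay, with a stated time of 72 h; on this read-out higher numbers stand for weaker inhibition and lower numbers for stronger inhibition:
- Compound 1 `COc1ccccc1N1C(=O)CSC1c1cccc(C(=O)NCCCCn2cccn2)c1`: 91.7 nM
- Compound 2 `COc1ccccc1N1C(=O)CSC1c1cccc(C(=O)NCCCCc2cccs2)c1`: 46 nM
- Compound 3 `COc1ccccc1N1C(=O)CSC1c1cccc(C(=O)NCCCCN2C(=O)C=CC2=O)c1`: > 1000 nM (a limit of the assay, not a number)

Going by the values given here, compound 1 gives 91.7 nM, and its only neighbour with a true number cannot be told apart from it: a 2.0-fold lower number from compound 1 to compound 2 (0.30 log units; within the scatter). Compound 4 `O=C(NCCCCn1cccn1)c1cccc(C2SCC(=O)N2c2cc(Cl)ccn2)c1` keeps the side chain of compound 1 and exchanges one group: 4-chloropyridin-2-yl in place of 2-methoxyphenyl on an amide-type nitrogen in a ring. Among the compounds with values here, no measured step touches that place. Within the data shown here, the only large steps, an at least 10-fold higher number from compound 1 to compound 3 (1.03 log units; beyond the scatter) and an at least 21-fold higher number from compound 2 to compound 3 (1.33 log units; beyond the scatter), lie on the side chain, yet they show that a single swap can cost much in this assay. A moderate move toward weaker inhibition is therefore expected, with wide uncertainty. The expected step is a 2.2-fold higher number from compound 1 to compound 4 (0.34 log units; beyond the scatter). For compound 4 the estimate is 200 nM, with an expected range from 60 nM to 700 nM.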

Compound 4, half-maximal inhibitory concentration: 36.4 nM
Compound 4: middle estimate off by 5.5-fold (0.74 log units), on the high side; the whole stated range lies above it.
By their numbers in this assay, from the lowest: compounds 4, 2 and 1 (each within the scatter of the next, the first and the last beyond it). At a limit, above all of these: compound 3.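

In this assay, placing 4-chloropyridin-2-yl instead of 2-methoxyphenyl on the amide-type nitrogen in a ring gives a 2.5-fold lower number from compound 1 to compound 4 (0.40 log units; beyond the scatter). Going by these compounds alone, the earlier steps all lay on the side chain, so this is the first sign that this place can also shift inhibition, and that 2-methoxyphenyl can be replaced there without loss. Nothing measured here explains this gain.

Going by these compounds, the exchange brings in a chlorine and a ring nitrogen together, so it remains open whether 4-chlorophenyl or unsubstituted pyridin-2-yl would do the same. On these data alone, whether the gain carries over to the thiophen-2-yl side chain of compound 2 also remains open.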